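The compounds below may be only part of what the source reports. "The series", "measured", "known", "first", "only" and "open" are said of these compounds alone.

Compound 1 `O=C(NCCCCc1ccccc1)c1cccc(C2SCC(=O)N2c2ccccn2)c1`: 19.7 nM
Compound 2 `COc1ccc(C)cc1N1C(=O)CSC1c1cccc(C(=O)NCCCCc2ccccc2)c1`: 300 nM
Compound 3 `CCN1C(=O)CSC1c1cccc(C(=O)NCCCCc2ccccc2)c1`: a limit of the assay, > 1000 nM

In a functional assay on HOS-TE85 cells (Homo sapiens) for inhibition, read by CCK-8 assay, with a stated time of 72 h (a higher number here means a weaker inhibitor, a lower number a stronger inhibitor), compound 1 gives 19.7 nM, the lowest of the two plain numbers shown. Compound 2 gives a weaker result, a 15-fold higher number from compound 1 to compound 2 (1.18 log units; beyond the scatter), after the group on the amide-type nitrogen in the ring is exchanged. For compound 3 the assay reports only a limit, (the limit of > 1000 nM in this assay, at which 1 of the 3 values shown sits), and not a number. Compound 3 is weaker than compound 2 by an at least 3.3-fold higher number from compound 2 to compound 3 (0.52 log units; beyond the scatter) and weaker than compound 1 by an at least 50-fold higher number from compound 1 to compound 3 (1.70 log units; beyond the scatter).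

Compound 4 `O=C(NCCCCc1ccccc1)c1cc(F)cc(C2SCC(=O)N2c2ccccn2)c1` differs from compound 1 in a single place: fluoro in place of hydrogen on an aromatic carbon. Within the data shown here, none of the measured steps bears on this position; all three exchange the group on the amide-type nitrogen in the ring, and they show that this part of the shared core is sensitive. The aromatic ring carrying the amide has not been varied among the measured compounds, so nothing shown points to a change in either direction. The step of a 1.0-fold higher number from compound 1 to compound 4 (0.01 log units; within the scatter) is therefore expected to stay within the scatter of repeated measurements. Compound 4 is estimated at 20 nM in this assay, with a range from 7 nM to 60 nM.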

Compound 4, half-maximal inhibitory concentration: 14.2 nM
Compound 4: the middle estimate sits 1.4-fold (0.15 log units) above what was measured; the measured number falls inside the stated range.
By their numbers in this assay, from the lowest: compounds 4 and 1 (each within the scatter of the next); then compound 2. At a limit, above all of these: compound 3.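

Putting fluoro in place of hydrogen on this aromatic carbon, meta to two large groups, gives a 1.4-fold lower number from compound 1 to compound 4 (0.14 log units; within the scatter) in this assay for this pair. Among these compounds, this is the first measured change away from the amide-type nitrogen in the ring, where all the earlier exchanges gave steps beyond the scatter. Here, a single fluorine atom on the other aromatic ring leaves compound 4 indistinguishable from compound 1, so this position accepts this one small change without a detectable loss or gain in the cell assay. No measurement shown explains this outcome.

The compounds shown leave open whether this position would also accept something larger than one atom, such as trifluoromethyl, an amine or a carboxylic acid, since a single fluoro says little about how much room for change there is. They also leave open whether fluoro would behave the same way on the other carbons of this ring, or whether a longer chain on the amide would change the picture.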